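Tert-butyl on the amide nitrogen: compound 2 to compound 3

A few compounds are considered here, and "the series" means these few. Any claim that something is new, unique, unknown or untested is made for them only; others in the source may bear on it.

Two members of this series have been measured in an in vitro assay on BaF3 cells for displacement of a labelled ligand from C-X-C chemokine receptor type 3 (Homo sapiens); on this read-out lower numbers stand for stronger inhibition and higher numbers for weaker inhibition. Compound 1 `CC[C@H]1CN(c2nc(N)c(C(=O)NCC(C)O)nc2Cl)CCN1C1CCN(Cc2ccc(Cl)cc2)CC1` gives 0.3 nM in this assay, and compound 2 `CC[C@H]1CN(c2ncc(C(N)=O)nc2Cl)CCN1C1CCN(C(=O)c2ccc(Cl)nc2N)CC1` gives 2.5 nM. Compound 2 therefore holds the higher of the two numbers, and the gap to compound 1 lies beyond the scatter; since the two differ at several places, nothing more is drawn from that pair.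

Compound 3 `CC[C@H]1CN(c2ncc(C(=O)NC(C)(C)C)nc2Cl)CCN1C1CCN(C(=O)c2ccc(Cl)nc2N)CC1` is built from compound 2 by one change, (tert-butyl in place of hydrogen on an amide-type nitrogen), on the amide-type nitrogen whose other neighbour is the carbonyl carbon. For the measured compounds named here, no measured pair shows this change, so its size is unknown. The tert-butyl group adds no donors or acceptors, and in this assay a modest step is expected from compound 2 to compound 3, a 1.7-fold lower number from compound 2 to compound 3 (0.22 log units; within the scatter), towards a slightly lower number. Compound 3 is thus estimated at 1.5 nM, with a range from 0.4 nM to 6 nM.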

Compound 3, half-maximal inhibitory concentration: 1.5 nM
Compound 3: the middle estimate sits on the measured number at the digits printed; the measured number falls inside the stated range.
By their numbers in this assay, from the lowest: compound 1; then compounds 3 and 2 (each within the scatter of the next).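

In this assay the replacement of the amide hydrogen by tert-butyl gives a 1.7-fold lower number from compound 2 to compound 3 (0.22 log units; within the scatter), so compound 2 and compound 3 cannot be told apart on this read-out. For the compounds shown here, this is the first pair that differs in one place, and it shows that this amide-type nitrogen can carry tert-butyl, rather than hydrogen, with no separation beyond the scatter. Nothing available here offers an explanation for this result.

The compounds shown leave open whether this nitrogen tolerates groups of another kind equally, such as a longer chain ending in a carboxylic acid or an amine. They also leave open whether the same replacement would read alike on the core of compound 1, which differs from compound 2 at several places.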